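Chain Extension on the Styryl Pyrrolidine Series

The compounds below may be only part of what the source reports. "The series", "measured", "known", "first", "only" and "open" are said of these compounds alone.

Of the compounds shown here, three have been measured in a functional assay on FL5.12 cells (Mus musculus) for cytotoxicity, read by flow cytometry, with a stated time of 48 h; on this read-out higher numbers stand for weaker inhibition and lower numbers for stronger inhibition. Compound 1 `CCCCCCCCCCCCC/C=C/[C@@H](O)[C@H](CO)NC(C)=O` gives 33000 nM. Compound 2 `CCCC/C=C/c1ccc(CO[C@@H]2CN[C@@H](CO)C2)cc1` gives 5500 nM, and compound 3 `CCCCCC/C=C/c1ccc(CO[C@@H]2CN[C@@H](CO)C2)cc1` gives 1400 nM, the lowest number of the three. Going by the values given here, the step of a 3.9-fold lower number from compound 2 to compound 3 (0.59 log units; beyond the scatter) is the only one among the measured compounds that bears on the next change. Compound 4 `CCCCCCCCCC/C=C/c1ccc(CO[C@@H]2CN[C@@H](CO)C2)cc1` differs from compound 3 by butyl in place of hydrogen on a saturated chain carbon, six bonds along the chain from a double-bonded chain carbon. Since lengthening the chain gave the step of a 3.9-fold lower number from compound 2 to compound 3 (0.59 log units; beyond the scatter), a further extension is expected to move this assay in the same direction, though a longer change on the same chain need not repeat that step in full. Compound 4 is therefore estimated at 500 nM, with a range from 150 nM to 2000 nM, a step of a 2.8-fold lower number from compound 3 to compound 4 (0.45 log units; beyond the scatter) expected.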

Compound 4, half-maximal inhibitory concentration: 2800 nM
The estimate for compound 4 lay 5.6-fold (0.75 log units) below the measured number; the whole stated range lies below it.
By their numbers in this assay, from the lowest: compounds 3, 4 and 2 (each within the scatter of the next, the first and the last beyond it); then compound 1.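

In this assay, butyl in place of hydrogen on a saturated chain carbon, six bonds along the chain from a double-bonded chain carbon, gives a 2.0-fold higher number from compound 3 to compound 4 (0.30 log units; within the scatter), so the earlier drop does not continue at this length. Going from the shortest chain of this series to the longest gives a 2.0-fold lower number from compound 2 to compound 4 (0.29 log units; within the scatter), leaving the longest and shortest chains of this series within the scatter of each other. No evidence on hand accounts for this result. On these data alone, how a chain of intermediate length, or an amine or a carboxylic acid on that chain, would read in this assay stays open.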